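Swapping the aryl group on the piperazine of compound 1

The compounds below may be only part of what the source reports. "The series", "measured", "known", "first", "only" and "open" are said of these compounds alone.

Of the compounds shown here, three sharing one core have been tested so far. Compound 1 `Nc1scc(CN2CCN(c3ccc(OC(F)(F)F)cc3)CC2)c1C(=O)c1ccc(Cl)cc1`, compound 2 `Nc1scc(CN2CCN(c3ccc(C(F)(F)F)cc3)CC2)c1C(=O)c1cccc(C(F)(F)F)c1` and compound 3 `Nc1scc(CN2CCN(c3cccc(F)c3)CC2)c1C(=O)c1cccc(C(F)(F)F)c1` differ in the aryl group on the amine nitrogen of the ring and in the ketone-side aryl. In a functional assay on CHO cells with adenosine receptor A1 (Homo sapiens) as the target, read by cAMP accumulation and immunoassay, with a stated time of 6 min, tested at 10 uM (on this read-out higher numbers stand for a weaker effect at the one concentration tested and lower numbers for a stronger effect), compound 1 gives -74%, the lowest of the three numbers and therefore the strongest effect seen. Compound 2 gives -47%, and compound 3 gives -62%.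

Among the compounds with values here, one measured step bears on the aryl group attached to the ring nitrogen: a number 15 percentage points lower from compound 2 to compound 3 (beyond the scatter). That change, like the one considered here, replaces the aryl on that nitrogen with a fluorine-bearing phenyl, and it moved the read-out only modestly.

Compound 4 `Nc1scc(CN2CCN(c3c(F)cccc3F)CC2)c1C(=O)c1ccc(Cl)cc1` arises from compound 1 by 2,6-difluorophenyl in place of 4-(trifluoromethoxy)phenyl on an amine nitrogen in a ring. Within the data shown here, no measured pair tests exactly this replacement, so the step from compound 2 to compound 3 is the only guide, and it suggests that changing this group shifts the read-out by a modest amount. Because compound 1 gives -74%, the expected step of a number 9 percentage points higher from compound 1 to compound 4 (within the scatter) is small and could go either way. Compound 4 is therefore estimated at -65%, with a likely range from -85% to -40%.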

Compound 4, a percentage reported as activity, at one concentration (the size of the read-out at that concentration, not a potency): -80%
For compound 4 the middle estimate is 15 percentage points above the measured one, and the stated range covers the measured number.
By their numbers in this assay, from the lowest: compounds 4 and 1 (each within the scatter of the next); then compound 3; then compound 2.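

In this assay, 2,6-difluorophenyl in place of 4-(trifluoromethoxy)phenyl gives a number 6 percentage points lower from compound 1 to compound 4 (within the scatter), so the read-out does not separate these two groups on the amine nitrogen of the six-membered ring. Within the data shown here, this is the first single-place change at this nitrogen with the ketone-side aryl of compound 1 held fixed, and it shows that a smaller aryl group without the oxygen can take the place of the larger one with no change beyond the scatter, whereas a number 15 percentage points lower from compound 2 to compound 3 (beyond the scatter), with the ketone-side aryl of compound 2, went beyond it. Nothing available explains why the two swaps differ in this way.

The compounds shown carry only fluorine-bearing phenyl groups on this nitrogen, so it remains open whether a plain phenyl, a phenyl carrying an amine or a carboxylic acid, or a non-aromatic group such as cyclohexyl would keep the read-out in the same range. As far as these compounds go, it is also open whether 2,6-difluorophenyl would behave the same way with the ketone-side aryl of compound 2, and a read-out at one concentration does not give the potency of either compound.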